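The compounds below may be only part of what the source reports. "The series", "measured", "known", "first", "only" and "open" are said of these compounds alone.

Of the compounds shown here, three built on one shared core have been tested in an assay on isolated protein for displacement of a labelled ligand from 5-hydroxytryptamine receptor 6 (Homo sapiens), read by radioligand binding; a higher number here means a weaker inhibitor, a lower number a stronger inhibitor. Compound 1 `Cc1cc(S(=O)(=O)Nc2ccc3c(c2)CCN(C)CC3)ccc1-c1ccc(Cl)cc1` gives 5.01 nM. Compound 2 `CN1CCc2ccc(NS(=O)(=O)c3ccc(-c4ccc(F)c(Cl)c4)cc3)cc2CC1` gives 7.94 nM, and compound 3 `CN1CCc2ccc(NS(=O)(=O)c3ccc(-c4ccc(Cl)cc4)s3)cc2CC1` gives 3.98 nM. These three numbers lie within the usual scatter of repeated measurements of one another, so none of them can be called stronger or weaker than the rest, and compound 2 sits among them rather than apart from them. The unmeasured compound 4 `CN1CCc2ccc(NS(=O)(=O)c3ccc(-c4ccc(C#N)cc4)cc3)cc2CC1` differs from compound 2 in a single place: 4-cyanophenyl in place of 3-chloro-4-fluorophenyl on an aromatic carbon. Within the data shown here, no pair of measured compounds shows this exact exchange, so its effect can only be judged from the spread seen so far, where exchanging one end group on the outer ring for another moved the numbers little. The expected change in this assay is therefore small, with at most a modest drift toward a higher number: a 1.3-fold higher number from compound 2 to compound 4 (0.10 log units; within the scatter). Compound 4 is estimated at 10 nM, within a range of 3 nM to 40 nM.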

Compound 4, inhibition constant: 25.1 nM
Compound 4: the middle estimate sits 2.5-fold (0.40 log units) below what was measured; low and high end bracket the measured number.
By their numbers in this assay, from the lowest: compounds 3, 1 and 2 (each within the scatter of the next); then compound 4.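

Among these compounds, on the outer ring, at an aromatic carbon para to a large group, the earlier compounds offered no exchange in a single place, so they could not show whether the end group matters there. In this assay, 4-cyanophenyl in place of 3-chloro-4-fluorophenyl gives a 3.2-fold higher number from compound 2 to compound 4 (0.50 log units; beyond the scatter), so this position does respond to the choice of end group, although the step is modest and both groups count the same number of heavy atoms. No measurement here explains why the number rises.

This one exchange adds the nitrile and removes both halogens at once, so their separate contributions cannot be told apart. It also leaves open whether a lone fluorine, a methoxy group or an amine on this ring would keep the number near that of compound 2.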